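The source may hold more compounds than are shown below. What is called first, only, known or untested is meant among the compounds shown, and "the series" means these compounds.

In a functional assay on HT-29 cells (Homo sapiens) for inhibition, read by MTT assay, with a stated time of 48 h (a lower number here means a stronger inhibitor, a higher number a weaker inhibitor), compound 1 `CCSc1nnc(-c2cc(OC)c(OC)c(OC)c2)n1-c1ccc(OC)cc1` stands at > 60000 nM as a limit only. Compound 2 `COc1ccc(-n2c(SCC(=O)c3ccccc3)nnc2-c2cc(OC)c(OC)c(OC)c2)cc1` stands at > 60000 nM as a limit too. Compound 3 `CCSc1nnc(-c2cc(OC)c(OC)c(OC)c2)n1-c1ccc(N(C)C)cc1` sits at > 60000 nM as a limit as well, so it offers no number to start from. Compound 4 `COc1ccc(C(=O)CSc2nnc(-c3cc(OC)c(OC)c(OC)c3)n2-c2ccc(N(C)C)cc2)cc1` departs from compound 3 through (4-methoxyphenyl)carbonyl in place of methyl on a saturated chain carbon bound to a sulfur on the same core. Going by the values given here, two steps bear on this, a step that the two limits leave unreadable from compound 1 to compound 2 with benzoyl in place of methyl and a step that the two limits leave unreadable from compound 1 to compound 3 with dimethylamino in place of methoxy, and neither has a size. The series stands at the limit of > 60000 nM in this assay, at which 3 of the 3 values shown sit, and gives no size to carry over. Expected here is an at least 1.5-fold lower number from compound 3 to compound 4 (0.17 log units; that floor lies within the scatter) in the direction of a stronger inhibitor, and no large change is expected. Compound 4 is estimated at 40000 nM within an expected range of 8000 nM to 60000 nM in this assay with a real chance of another limit.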

Compound 4, half-maximal inhibitory concentration: 64000 nM
Beside the measured number, compound 4's estimate is 1.6-fold (0.20 log units) below it; the whole stated range lies below it.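

In this assay, going by these compounds alone, compound 3 stands only at the limit > 60000 nM and so no step from it to compound 4 can be read. The compounds shown leave open the size of every step in the series: the limit of > 60000 nM in this assay, at which 3 of the 4 values shown sit.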